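Trifluoromethoxy in place of trifluoromethyl at two ring positions

This account rests on a few compounds, and the source may have more. Where it says the series, first, only, none or still open, it means among the compounds named here.

Of the compounds shown here, three have been measured in an assay on HEK293 cells for antagonist activity at transient receptor potential cation channel subfamily V member 3 (Homo sapiens), read by FLIPR and calcium flux; a lower number here means a stronger inhibitor, a higher number a weaker inhibitor. Compound 1 `C[C@]1(O)C[C@](c2cccc(OC(F)(F)F)c2)([C@H](O)c2ccccn2)C1` gives 1310 nM, compound 2 `C[C@]1(O)C[C@](c2cccc(C(F)(F)F)c2)([C@H](O)c2ccccn2)C1` gives 1550 nM and compound 3 `C[C@]1(O)C[C@@](c2ccc(C(F)(F)F)cc2)([C@H](O)c2ccccn2)C1` gives 840 nM. Compound 4 `C[C@]1(O)C[C@@](c2ccc(OC(F)(F)F)cc2)([C@H](O)c2ccccn2)C1` has not yet been measured.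

The change from compound 2 to compound 1 is trifluoromethoxy in place of trifluoromethyl on an aromatic carbon; it made a step of a 1.2-fold lower number from compound 2 to compound 1 (0.07 log units; within the scatter). Compound 3 has the same atoms as compound 2 joined differently; the difference between the two cores is not broken down here. Among the three measured numbers compound 3 has the lowest, but its gaps to compound 1 and to compound 2 both lie within the scatter, so no order among the three is claimed.

The change from compound 3 to compound 4 is trifluoromethoxy in place of trifluoromethyl on an aromatic carbon. Among the measured compounds shown here, it is the same kind of change as the one from compound 2 to compound 1, not the same: there the group sits meta to a large group, here para to a large group. Because a 1.2-fold lower number from compound 2 to compound 1 (0.07 log units; within the scatter) stayed within the scatter, the step to compound 4 is expected to be about a 1.1-fold lower number from compound 3 to compound 4 (0.05 log units; within the scatter). The estimate for compound 4 in this assay is 750 nM, with an expected range from 350 nM to 1600 nM; it rests on a single precedent and keeps the full width of the scatter.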

Compound 4, antagonist equilibrium constant: 330 nM
For compound 4 the middle estimate is 2.3-fold (0.36 log units) above the measured one; measured number outside the range, below it.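

In this assay, among the compounds shown here, trifluoromethoxy in place of trifluoromethyl, para to a large group, gives a step of a 2.5-fold lower number from compound 3 to compound 4 (0.41 log units; beyond the scatter), and this is the only step of this change that lies beyond the scatter. Set beside the earlier step, the gap between the two cores also stays within the scatter, so the data give no ground for saying that the change behaves differently from one core to the other: the same change on two cores in this assay, a 1.2-fold lower number (0.07 log units; within the scatter) from compound 2 to compound 1 and a 2.5-fold lower number (0.41 log units; beyond the scatter) from compound 3 to compound 4, 2.2-fold (0.33 log units) apart, within the scatter of two such steps. For the compounds shown here, this does not show that the step carries over unchanged, nor that it depends on the core: there is only one pair on each core, and the two pairs differ both in where the group sits and in how the core is joined, so neither difference can be singled out.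

The compounds shown leave open whether the step to trifluoromethoxy would hold on further cores of the series, or with the group at another place on the aromatic ring. They also leave open how other groups at the same place would compare, such as a nitrile or a chlorine atom, and what an amine in place of either hydroxyl group would do to the number.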